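A few compounds are considered here, and "the series" means these few. Any claim that something is new, unique, unknown or untested is made for them only; others in the source may bear on it.

Compound 1 `CCCCc1cnc(Cc2ccc(-c3ccccc3C(=O)O)cc2)[nH]1`: > 10000 nM
Compound 2 `COc1cccc(Cc2cnc(CCc3ccc(-c4ccccc4C(=O)O)cc3)[nH]2)c1`: 4120 nM

For the measured compounds named here, in an in vitro functional assay on cells for agonist activity at Bombesin receptor subtype-3 (Homo sapiens), read by luminescence and calcium flux (on this read-out lower numbers stand for an effect already at smaller amounts and higher numbers for an effect only at larger amounts of compound), compound 2 gives 4120 nM, the only number among the two results. Compound 1 reaches only (the limit of > 10000 nM in this assay, at which 1 of the 2 values shown sits). Compound 3 `O=C(O)c1ccccc1-c1ccc(CCc2ncc(CCc3ccccc3)[nH]2)cc1` differs from compound 2 by one change: benzyl in place of 3-methoxyphenyl on a saturated chain carbon bound to an aromatic carbon. Going by the values given here, no measured pair of compounds differing in a single place is available to gauge such a change, so the size of the step is uncertain; a modest shift toward a larger amount, not clearly beyond the scatter, is expected. The expected step of a 1.5-fold higher number from compound 2 to compound 3 (0.16 log units; within the scatter) is therefore small. Compound 3 is estimated at 6000 nM, in a range from 2000 nM to 20000 nM.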

Compound 3, half-maximal effective concentration: 1320 nM
Estimate against measurement, compound 3: 4.5-fold (0.66 log units) above, outside the stated range (below it).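

In this assay, for the compounds shown here, putting benzyl in place of 3-methoxyphenyl on a saturated chain carbon bound to an aromatic carbon gives a 3.1-fold lower number from compound 2 to compound 3 (0.49 log units; beyond the scatter) as the first readable single change. This place therefore responds to what is attached there, and the methoxy oxygen is not needed for the response seen in compound 3. Nothing shown here explains the gain.

This single step cannot separate losing the methoxy from the changed chain, since the same difference also reads 3-methoxybenzyl to phenethyl. Going by these compounds, how an amine or a longer chain at this place would read remains open.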